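The source may report more compounds than this note shows. Statements on the series, on what has been measured and on what is new or still open speak of the compounds shown alone.

Measured so far in a functional assay on HepG2 cells (Homo sapiens) for cytotoxicity, read by MTT assay, with a stated time of 72 h; on this read-out higher numbers stand for weaker inhibition and lower numbers for stronger inhibition:

Compound 1, `O=C(Nc1ccc(Oc2ccnc3[nH]ccc23)c(F)c1)c1nn(-c2ccc(Br)cc2)ccc1=O`, gives 68000 nM.
Compound 2, `O=C(Nc1ccc(Oc2ccnc3[nH]ccc23)c(F)c1)c1nn(-c2ccc(Br)cc2F)ccc1=O`, gives 56500 nM.
Compound 3, `Cc1cc(=O)n(-c2ccccc2OC(F)(F)F)nc1C(=O)Nc1ccc(Oc2ncnc3c2ccn3C)cc1`, gives only a limit of the assay, > 60000 nM.

Compound 1 and compound 2 share one core and differ by a single change, (fluoro in place of hydrogen on an aromatic carbon). The step this made is a 1.2-fold lower number from compound 1 to compound 2 (0.08 log units; within the scatter), so the two numbers cannot be told apart. For compound 3 no number is known, only (the limit of > 60000 nM in this assay, at which 1 of the 3 values shown sits). Compound 3 is built on a different core from compound 1; the difference between the two cores is not broken down here.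

Compound 4, `Cc1cc(=O)n(-c2ccccc2OC(F)(F)F)nc1C(=O)Nc1ccc(Oc2ncnc3c2ccn3C)c(F)c1`, has not yet been measured. It arises from compound 3 by fluoro in place of hydrogen on an aromatic carbon. Among the measured compounds shown here, this is the same kind of change as the one from compound 1 to compound 2, but not the same: in compound 2 the fluoro sits meta to a bromo group (1 heavy atom), while in compound 4 it sits meta to a large group.

The expected step for compound 4 is a number no higher from compound 3 to compound 4 (the limit leaves the size open), and this rests on a 1.2-fold lower number from compound 1 to compound 2 (0.08 log units; within the scatter), a step that lay within the scatter, together with the fact that compound 3 reached only a limit. Compound 4 is therefore estimated at 60000 nM, most likely again reported as a limit rather than a number, with a range expected from 30000 nM to 150000 nM.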

Compound 4, half-maximal inhibitory concentration: > 60000 nM
Compound 4: a limit, no number; the forecaster's own chance of this, stated with the estimate: 70%; the middle value lies on the limit itself.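

No step can be read from compound 3 to compound 4, because each compound gives only a limit of the assay and not a number in this assay: the limit of > 60000 nM in this assay, at which 2 of the 4 values shown sit.

The compounds shown leave open how the true numbers of compound 3 and compound 4 compare, and so whether fluoro in place of hydrogen on their shared core changes the result at all.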